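From ethylsulfonyl to phenylsulfonyl on the shared core

The compounds below may be only part of what the source reports. "The series", "measured", "known", "first", "only" and "open" are said of these compounds alone.

In a functional assay on MDA-MB-231 cells (Homo sapiens) for antiproliferative activity, read by XTT assay, with a stated time of 48 h (on this read-out lower numbers stand for stronger inhibition and higher numbers for weaker inhibition), compound 1 `CC(=O)OC[C@H]1O[C@@H](n2cc(CN(c3ccc(C#N)cc3)S(C)(=O)=O)nn2)[C@H](OC(C)=O)[C@@H]1OC(C)=O` gives 100000 nM. In the same test compound 2 `CCCCCCN(Cc1cn([C@@H]2O[C@H](COC(C)=O)[C@@H](OC(C)=O)[C@H]2OC(C)=O)nn1)S(C)(=O)=O` gives 225000 nM, and compound 3 `CCS(=O)(=O)N(Cc1cn([C@@H]2O[C@H](COC(C)=O)[C@@H](OC(C)=O)[C@H]2OC(C)=O)nn1)c1ccc(Cl)cc1` gives 250000 nM. The values of compound 3 and compound 2 lie within the scatter of each other, while compound 1 shows the lower number of the set.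

Compound 4 `CC(=O)OC[C@H]1O[C@@H](n2cc(CN(c3ccc(Cl)cc3)S(=O)(=O)c3ccccc3)nn2)[C@H](OC(C)=O)[C@@H]1OC(C)=O` departs from compound 3 at a single place: phenyl in place of ethyl on a sulfonyl sulfur. In words, it carries phenyl in place of ethyl on a sulfonyl sulfur. Going by the values given here, no measured step changes the group at that sulfur. Among the compounds with values here, the only step available is a 2.3-fold higher number from compound 1 to compound 2 (0.35 log units; beyond the scatter), a modest one that concerns a group on a sulfonamide nitrogen, so it bears on this change only indirectly. With that little guidance, no step beyond the scatter is expected in this assay. The estimated step is a 1.4-fold lower number from compound 3 to compound 4 (0.14 log units; within the scatter). For compound 4 the expected value is 180000 nM, with an estimated range from 70000 nM to 400000 nM.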

Compound 4, half-maximal inhibitory concentration: 250000 nM
Beside the measured number, compound 4's estimate is 1.4-fold (0.14 log units) below it; the range from low to high includes it.
By their numbers in this assay, from the lowest: compound 1; then compounds 2, 3 and 4 (each within the scatter of the next).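

In this assay, phenyl in place of ethyl on a sulfonyl sulfur gives no change at the digits printed from compound 3 to compound 4 (within the scatter). Going by these compounds alone, the earlier compounds offered only a step at the sulfonamide nitrogen, and this is the first reading at the sulfur itself, where an aromatic ring takes the place of ethyl with no step beyond the scatter. Nothing measured on these compounds speaks to why the two groups read alike.

The compounds shown leave open whether a phenylsulfonyl group carrying an amine or a carboxylic acid, or a longer chain at the sulfur, would read any differently from compound 4. They also leave open whether the same change would read alike with 4-cyanophenyl on the sulfonamide nitrogen, the group of compound 1, which gives 100000 nM.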